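This account rests on a few compounds, and the source may have more. Where it says the series, first, only, none or still open, it means among the compounds named here.

Measured compounds in an assay on isolated protein for displacement of a labelled ligand from Gonadotropin-releasing hormone receptor (Rattus norvegicus); on this read-out lower numbers stand for stronger inhibition and higher numbers for weaker inhibition:

- compound 1, `CCc1cc(CN2CCN(c3cccc4[nH]c(-c5ccc(C(C)(C)C)cc5)nc34)CC2)nn1C`, 350 nM
- compound 2, `CCCn1cnc(CN2CCN(c3cccc4[nH]c(-c5ccc(C(C)(C)C)cc5)nc34)CC2)c1C`, 47 nM
- compound 3, `Cc1nc(CN2CCN(c3cccc4[nH]c(-c5ccc(C(C)(C)C)cc5)nc34)CC2)cn1C`, 34 nM

Compound 3 gives the lowest of the three numbers, but its separation from compound 2 is small: a 1.4-fold lower number from compound 2 to compound 3 (0.14 log units; within the scatter). Against compound 1 it stands clearly apart: a 10-fold lower number from compound 1 to compound 3 (1.01 log units; beyond the scatter). The other measured step, a 7.4-fold lower number from compound 1 to compound 2 (0.87 log units; beyond the scatter), runs the same way and shows that most of the spread in this set comes from swapping the five-membered ring attached to the saturated chain carbon bound to the amine nitrogen, not from the alkyl group on the ring nitrogen.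

Compound 4, `CCn1cc(CN2CCN(c3cccc4[nH]c(-c5ccc(C(C)(C)C)cc5)nc34)CC2)nc1C`, keeps the ring of compound 3 and differs only by methyl in place of hydrogen on a saturated chain carbon bound to an aromatic nitrogen. Going by the values given here, no measured pair changes just this substituent; the closest comparison is the step from compound 2 to compound 3, which includes a propyl-to-methyl exchange on the aromatic nitrogen together with a methyl shift and stays within the scatter. On that basis the step of a 1.0-fold higher number from compound 3 to compound 4 (0.01 log units; within the scatter) is expected to be small and not beyond the scatter, with no preferred direction. Compound 4 is therefore estimated at 35 nM, within 15 nM to 85 nM.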

Compound 4, half-maximal inhibitory concentration: 51 nM
Beside the measured number, compound 4's estimate is 1.5-fold (0.16 log units) below it, within the range that was stated.
By their numbers in this assay, from the lowest: compounds 3, 2 and 4 (each within the scatter of the next); then compound 1.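

In this assay, going by these compounds alone, the methyl-to-ethyl change on the aromatic nitrogen of the 1,2-dimethyl-1H-imidazol-4-yl group gives the first direct reading at this position: with a 1.5-fold higher number from compound 3 to compound 4 (0.18 log units; within the scatter), one added carbon on a saturated chain carbon bound to an aromatic nitrogen leaves the number unchanged within the scatter. The 1-ethyl-2-methyl-1H-imidazol-4-yl group also stays level with the 5-methyl-1-propyl-1H-imidazol-4-yl group, with a 1.1-fold higher number from compound 2 to compound 4 (0.04 log units; within the scatter), and keeps clear of the 5-ethyl-1-methyl-1H-pyrazol-3-yl group, with a 6.9-fold lower number from compound 1 to compound 4 (0.84 log units; beyond the scatter), so compound 2, compound 3 and compound 4 form one group apart from compound 1, and no compound shown goes against this. Nothing measured here explains any of these steps.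

Open questions are whether the same position still holds the number with a longer chain such as butyl, a benzyl group, or a chain ending in an amine or a carboxylic acid. On these data alone, it is also open whether the methyl-to-ethyl change would read the same on the 5-ethyl-1-methyl-1H-pyrazol-3-yl group.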